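Cyclobutyl for Isopropyl on the Sulfonamide Nitrogen

A few compounds are considered here, and "the series" means these few. Any claim that something is new, unique, unknown or untested is made for them only; others in the source may bear on it.

Compound 3 `CC(C)NS(=O)(=O)c1ccc(S(=O)(=O)N2CCC[C@@H](C(=O)N3CCN(c4nc(C(C)C)no4)CC3)C2)cc1` carries an isopropylamino group on the sulfonyl sulfur. In a functional assay on MIA PaCa-2 cells (Homo sapiens) for inhibition, read by MTT assay, with a stated time of 3 days (on this read-out lower numbers stand for stronger inhibition and higher numbers for weaker inhibition), compound 3 gives only a limit, > 10000 nM. Compound 1 `CC(C)c1noc(N2CCN(C(=O)[C@@H]3CCCN(S(=O)(=O)c4ccc(S(=O)(=O)C5CCC5)cc4)C3)CC2)n1` has cyclobutyl at that place; in this assay compound 1 also gives only a limit, > 10000 nM. Compound 2 `CC(C)c1noc(N2CCN(C(=O)[C@@H]3CCCN(S(=O)(=O)c4ccc(S(=O)(=O)C(C)C)cc4)C3)CC2)n1` has isopropyl there; in this assay compound 2 likewise gives only a limit, > 10000 nM. The whole set therefore sits at the limit of > 10000 nM in this assay, at which 3 of the 3 values shown sit, and the steps a step that the two limits leave unreadable from compound 1 to compound 2, a step that the two limits leave unreadable from compound 1 to compound 3 and a step that the two limits leave unreadable from compound 2 to compound 3 cannot be sized.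

Compound 4 `CC(C)c1noc(N2CCN(C(=O)[C@@H]3CCCN(S(=O)(=O)c4ccc(S(=O)(=O)NC5CCC5)cc4)C3)CC2)n1` differs from compound 3 by cyclobutyl in place of isopropyl on a sulfonamide nitrogen. The measured steps that bear on this are the exchanges among cyclobutyl, isopropyl and isopropylamino on the sulfonyl sulfur, above all a step that the two limits leave unreadable from compound 1 to compound 2; each of them is unreadable, since both ends sit at the limit. No step beyond the scatter in this assay can be predicted from the numbers, nor can one be excluded, but the shared core with each of these three substituents has so far shown no measurable inhibition.

Compound 4 is therefore expected to return another limit, with an estimate of 20000 nM and a range of 8000 nM to 60000 nM. The estimated step that the limit leaves unreadable from compound 3 to compound 4 is expected to lie within the scatter.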

Compound 4, half-maximal inhibitory concentration: > 10000 nM
Compound 4: only a limit was reported; the forecaster's own chance of this, stated with the estimate: 85%; the middle value does not contradict the limit.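

In this assay compound 4 gives only a limit, > 10000 nM. Its steps to compound 1, compound 2 and compound 3 cannot be read. The compounds shown leave open whether any substituent at this place on the shared core gives a measurable value in this assay, and how these four compare with one another.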